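The source may report more compounds than this note shows. Statements on the series, on what has been measured and on what is new or still open speak of the compounds shown alone.

Compound 1, `CC1(C)[C@H](Br)[C@H](O)C[C@@]2(CO2)[C@@]12CCC(=O)[C@@H]1O[C@@H]12`: >= 10000 nM
Compound 2, `C=C1C[C@@H](O)[C@@H](Br)C(C)(C)[C@@]12C=C[C@](O)(C(Br)Br)CC2`: >= 10000 nM

Of the compounds shown here, two have so far been tested in a functional assay on DLD-1 cells (Homo sapiens) for cytotoxicity, read by resazurin assay; on this read-out lower numbers stand for stronger inhibition and higher numbers for weaker inhibition. In this assay compound 1 gives >= 10000 nM, which is a limit of the assay and not a number. Compound 2 gives >= 10000 nM in this assay, again only a limit rather than a measured value. Compound 2 thus stands at the limit of >= 10000 nM in this assay, at which 2 of the 2 values shown sit. Among the compounds with values here, compounds 1 and 2 differ in more than one place, and their two values show only that neither reaches a number the assay can report.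

The next compound, compound 3, `C=C1C[C@@H](O)[C@@H](Br)C(C)(C)[C@@]12C=C[C@](O)(CO)CC2`, differs from compound 2 in a single place: hydroxymethyl in place of dibromomethyl on a saturated ring carbon. Nothing measured here speaks to the effect of this change, and compound 2 offers only a limit as a starting point. The expected step is a number no higher from compound 2 to compound 3 (the limit leaves the size open), which would be no more than the usual scatter, with a real chance that the assay again returns only a limit. Compound 3 is therefore estimated at 10000 nM in this assay, with a range of 3000 nM to 30000 nM.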

Compound 3, half-maximal inhibitory concentration: >= 10000 nM
Compound 3 ended at the assay's limit; the forecaster's own chance of this, stated with the estimate: 75%; the middle value lies on the limit itself.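

Compound 2 and compound 3 both sit at a limit of the assay and not at a number, so the step between them, hydroxymethyl in place of dibromomethyl, cannot be read: the limit of >= 10000 nM in this assay, at which 3 of the 3 values shown sit. The compounds shown leave open whether this change has any effect in this assay and which compound, if any, would give a measurable value.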